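Swapping a Benzyl Ether for a Sulfonate: Cytotoxicity Outlook

This account rests on a few compounds, and the source may have more. Where it says the series, first, only, none or still open, it means among the compounds named here.

Compound 3 `CC(C)(C)[Si](CCc1c(OCc2c(Cl)cccc2Cl)nc2ccc(Cl)cc2c1-c1ccccc1Cl)(c1ccccc1)c1ccccc1` has been tested in an ADME assay on HepG2 2.2.15 cells (Homo sapiens) for cytotoxicity; a higher number here means that more compound is tolerated, a lower number that less compound is tolerated. In this assay compound 3 gives > 1020000 nM, which is a limit of the assay and not a number. Compound 1 `ClCCc1c(Cl)nc2ccc(Cl)cc2c1-c1ccccc1Cl` also reaches only a limit in this assay, > 1400000 nM. Compound 2 `CC(C)(C)[Si](CCc1c(OCc2c(F)cccc2F)nc2ccc(Cl)cc2c1-c1ccccc1Cl)(c1ccccc1)c1ccccc1` likewise gives only a limit, > 1860000 nM. Within the data shown here, compound 3 therefore stands at a limit, as do both other measured compounds, and the single measured step that the two limits leave unreadable from compound 2 to compound 3 has no readable size.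

Compound 4 `CC(C)(C)[Si](CCc1c(OS(=O)(=O)C(F)(F)F)nc2ccc(Cl)cc2c1-c1ccccc1Cl)(c1ccccc1)c1ccccc1` differs from compound 3 by (trifluoromethyl)sulfonyl in place of 2,6-dichlorobenzyl on an oxygen on an aromatic ring. Among the measured compounds shown here, the one measured step, a step that the two limits leave unreadable from compound 2 to compound 3, also changes the group on this oxygen, yet its size stays hidden. All three values shown sit at a limit (the limit of > 1020000 nM in this assay, at which 1 of the 3 values shown sits, (the limit of > 1400000 nM in this assay, at which 1 of the 3 values shown sits), (the limit of > 1860000 nM in this assay, at which 1 of the 3 values shown sits)), so nothing points to a step beyond the scatter. Compound 4 is expected to give 1500000 nM, within 700000 nM to 3000000 nM. The expected step that the limit leaves unreadable from compound 3 to compound 4 is thus no change beyond the scatter, and most likely another limit.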

Compound 4, half-maximal cytotoxic concentration: > 1560000 nM
Compound 4: only a limit was reported; the forecaster's own chance of this, stated with the estimate: 85%; at least 1.0-fold (0.01 log units) between middle value and limit.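

Compound 4 also reaches only a limit of the assay, as do compound 2 and compound 3, so neither step to compound 4 can be read. The compounds shown leave open at what concentration any of them harms these cells, and whether the group on this oxygen changes that.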